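The source may hold more compounds than are shown below. What is called first, only, known or untested is meant among the compounds shown, and "the series" means these compounds.

Measured so far in an assay on isolated protein for inhibition of protein tyrosine phosphatase type IVA 3 (Homo sapiens), tested at 5 ug/mL; on this read-out higher numbers stand for more inhibition at the one concentration tested (going by the name of the read-out) and lower numbers for less inhibition:
- compound 1 `COc1ccccc1COc1ccccc1/C=C/C=C1\SC(=S)NC1=O`: 78.8%
- compound 2 `O=C1NC(=S)S/C1=C\C=C\c1cccnc1`: 47.1%

Compound 1 stands highest of the two numbers; its nearest neighbour is compound 2, whose value lies lower by an amount beyond the usual scatter. Going by the values given here, no single-change step between measured compounds is available, so the two values can only be read side by side, not as a pattern.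

Compound 3 `COc1ccccc1/C=C/C=C1\SC(=S)NC1=O` has not yet been measured. It differs from compound 1 as follows: hydrogen in place of 2-methoxyphenyl on a saturated chain carbon bound to an oxygen on an aromatic ring

Among the compounds with values here, with no measured step to lean on, the expected direction is a drop, of moderate size, because compound 1 carries the larger group and gives 78.8% whereas the smaller compound 2 gives 47.1%. The step from compound 1 to compound 3 is estimated at a number 23.8 percentage points lower from compound 1 to compound 3 (beyond the scatter) in this assay. Compound 3 is therefore expected to give about 55%, within a range of 35% to 75%.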

Compound 3, a percentage reported as inhibition, at one concentration (the size of the read-out at that concentration, not a potency): 41.7%
Estimate against measurement, compound 3: 13.3 percentage points above, within the range that was stated.
By their numbers in this assay, from the lowest: compounds 3 and 2 (each within the scatter of the next); then compound 1.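

In this assay, going by these compounds alone, the first single-change step is a number 37.1 percentage points lower from compound 1 to compound 3 (beyond the scatter), a large loss on replacing 2-methoxyphenyl with hydrogen on a saturated chain carbon bound to an oxygen on an aromatic ring. Within the data shown here, this shows that inhibition at the one concentration tested depends on what sits at this place, which the side-by-side reading of the earlier compounds could not establish. Nothing available accounts for the size of this loss.

On these data alone, only 2-methoxyphenyl and hydrogen can be compared at this place, so it remains open whether the aromatic ring alone would retain the inhibition or whether its methoxy group is also needed. A plain phenyl, a cyclohexyl or a short chain such as ethyl would help separate these readings, as would an amine or a carboxylic acid on the ring.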